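Swapping methoxy for pentyl on a sulfonamide

A few compounds are considered here, and "the series" means these few. Any claim that something is new, unique, unknown or untested is made for them only; others in the source may bear on it.

Measured in a functional assay on M21 cells (Homo sapiens) for antiproliferative activity, read by sulforhodamine B assay, with a stated time of 48 h; on this read-out lower numbers stand for stronger inhibition and higher numbers for weaker inhibition:
compound 1 `O=C1NCCN1c1ccc(S(=O)(=O)Nc2ccc(F)cc2)cc1`: 230 nM
compound 2 `COc1ccc(NS(=O)(=O)c2ccc(N3CCNC3=O)cc2)cc1`: 580 nM

Compound 2, at 580 nM, has the higher of the two numbers, so it is the weaker inhibitor. Compound 3 `CCCCCc1ccc(NS(=O)(=O)c2ccc(N3CCNC3=O)cc2)cc1` keeps the shared core and changes one group: pentyl in place of methoxy on an aromatic carbon. Among the compounds with values here, only one measured step bears on this place, and it is modest: a 2.5-fold higher number from compound 1 to compound 2 (0.40 log units; beyond the scatter). Within the data shown here, a single step sets no firm trend, and no pentyl compound has been measured, so only a small further rise in this assay is expected, with wide uncertainty. The estimated step is a 1.4-fold higher number from compound 2 to compound 3 (0.14 log units; within the scatter). For compound 3 the expected value is 800 nM, with an estimated range of 200 nM to 3000 nM.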

Compound 3, half-maximal inhibitory concentration: 870 nM
Compound 3: the middle estimate sits 1.1-fold (0.04 log units) below what was measured; low and high end bracket the measured number.
By their numbers in this assay, from the lowest: compound 1; then compounds 2 and 3 (each within the scatter of the next).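

In this assay, pentyl in place of methoxy gives a 1.5-fold higher number from compound 2 to compound 3 (0.18 log units; within the scatter) and so cannot be told apart from methoxy at this place, despite the larger group. Pentyl in place of fluoro gives a 3.8-fold higher number from compound 1 to compound 3 (0.58 log units; beyond the scatter) and leaves compound 1 the strongest inhibitor of the three. Nothing measured here gives a reason for either step. On these data alone, it remains open whether a shorter chain, a longer chain, an amine or a carboxylic acid at this place would sit nearer to fluoro or to pentyl.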